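Fluorine on the benzyl group: expected effect on cell toxicity

A few compounds are considered here, and "the series" means these few. Any claim that something is new, unique, unknown or untested is made for them only; others in the source may bear on it.

In an ADME assay on HepG2 cells (Homo sapiens) for cytotoxicity, read by CellTiter-Glo and ATP content, with a stated time of 72 h (a lower number here means that less compound is needed, a higher number that more compound is needed for the effect), compound 1 `CS(=O)(=O)c1ccc(C(=O)N2CCC(C(=O)N3CCc4ccccc43)CC2)cc1[N+](=O)[O-]` reaches only the limit of the measurement, > 27000 nM. The change from compound 1 to compound 2 `CN(Cc1ccccc1)C(=O)C1CCN(C(=O)c2ccc(S(C)(=O)=O)c([N+](=O)[O-])c2)CC1` replaces one amide substituent with another, and compound 2 likewise reaches only the limit, > 27000 nM. Both values therefore sit at the same limit (the limit of > 27000 nM in this assay, at which 2 of the 2 values shown sit), and the step that the two limits leave unreadable from compound 1 to compound 2 cannot be read as a number. Compound 2 thus stands at the edge of what this assay can report, with no measured value to compare against. Compound 3 `CN(Cc1ccccc1F)C(=O)C1CCN(C(=O)c2ccc(S(C)(=O)=O)c([N+](=O)[O-])c2)CC1` differs from compound 2 by a single change, (fluoro in place of hydrogen on an aromatic carbon), in words fluoro in place of hydrogen on an aromatic carbon, ortho to a large group. No measured step speaks to this change, and nothing shown points toward cell toxicity appearing. For compound 3 the expected result is again a limit-sized value, estimated at 40000 nM within 20000 nM to 100000 nM, a step that the limit leaves unreadable from compound 2 to compound 3 no larger than the scatter.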

Compound 3, half-maximal effective concentration: > 27000 nM
Compound 3 ended at the assay's limit (the forecaster's own chance of this, stated with the estimate: 85%); the middle value is on the limit's open side.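

No step among compound 1, compound 2 and compound 3 can be read, because each value is only a limit: the limit of > 27000 nM in this assay, at which 3 of the 3 values shown sit.

Going by these compounds, how much of each compound would be needed for an effect in this assay, and whether fluoro in place of hydrogen changes that amount, stays open.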